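The compounds below may be only part of what the source reports. "The series", "measured", "known", "first", "only" and "open" are said of these compounds alone.

Compound 1 `O=C(Nc1cccc(-n2cc(-c3ccncc3)c(-c3ccc(Cl)c(O)c3)n2)c1)Nc1ccc(Cl)c(Cl)c1` gives > 32500 nM in a functional assay on PC-3 cells (Homo sapiens) for inhibition, read by sulforhodamine B assay, with a stated time of 48 h (a lower number here means that less compound is tolerated, a higher number that more compound is tolerated), which is a limit of the assay.
Compound 2 `COc1cc(-c2nn(-c3cccc(NC(=O)c4cccc(C(F)(F)F)c4)c3)cc2-c2ccncc2)ccc1Cl` gives > 50000 nM in this assay, again a limit.
Compound 3 `O=C(Nc1cccc(-n2cc(-c3ccncc3)c(-c3ccc(Cl)c(O)c3)n2)c1)Nc1cc(C(F)(F)F)cc(C(F)(F)F)c1` gives > 50000 nM in this assay, also a limit.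

Among the compounds with values here, compound 2 therefore stands at a limit, and so do the two other values shown (the limit of > 50000 nM in this assay, at which 2 of the 3 values shown sit, (the limit of > 32500 nM in this assay, at which 1 of the 3 values shown sits)); no compound here is known to reach a measurable number. Compound 4 `COc1cc(-c2nn(-c3cccc(NC(=O)Nc4ccc(Cl)c(C(F)(F)F)c4)c3)cc2-c2ccncc2)ccc1Cl` is built from compound 2 by the change ((4-chloro-3-(trifluoromethyl)phenyl)amino in place of 3-(trifluoromethyl)phenyl on a carbonyl carbon). Within the data shown here, no step between two measured compounds is available to size this change. Since all three values are limits, no step beyond the scatter is expected; compound 4 is estimated to remain at a limit, with a number no higher from compound 2 to compound 4 (the limit leaves the size open). The value of compound 4 is expected near 50000 nM, between 20000 nM and 120000 nM.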

Compound 4, concentration lethal to 50% of the cells: > 32500 nM
Compound 4 gave a limit, no number; the forecaster's own chance of this, stated with the estimate: 70%; the middle value does not contradict the limit.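

Compound 2 and compound 4 both stand at limits in this assay, and the step between them cannot be read. The compounds shown leave open whether the change from one to the other alters the lethal concentration at all.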